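The source may hold more compounds than are shown below. What is called first, only, known or untested is meant among the compounds shown, and "the series" means these compounds.

Values measured so far in a physicochemical assay for solubility, read by HPLC, in phosphate buffer, measured as kinetic solubility, at pH 7.4 (a lower number here means a less soluble compound, a higher number a more soluble compound), are:

- compound 1 `CCC(=O)c1cc(-c2ccc(Cl)cc2)n(C2CCN(S(N)(=O)=O)CC2)c1C` gives 27800 nM
- compound 2 `NS(=O)(=O)c1ccc(-c2cc(C(=O)C3CC3)nn2-c2ccc(Cl)cc2)cc1` gives 25600 nM

Compound 2 and compound 1 stand within the usual scatter of each other, and these two numbers cannot be told apart. The two structures differ in more than one place, and no measured single change is available as a guide. Compound 3 `NS(=O)(=O)c1ccc(-c2cc(C(=O)N3CCCCC3)nn2-c2ccc(Cl)cc2)cc1` keeps the rest of compound 2 but carries piperidin-1-yl in place of cyclopropyl on a carbonyl carbon in the structure. Put another way, cyclopropylcarbonyl becomes (piperidin-1-yl)carbonyl. Starting from compound 2 (25600 nM), a small step toward a lower number is expected in this assay, possibly no larger than the scatter. The estimated move is modest (a 1.4-fold lower number from compound 2 to compound 3 (0.15 log units; within the scatter)). For compound 3 the expected value is 18000 nM within an estimated range of 5000 nM to 45000 nM for most repeat measurements.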

Compound 3, solubility: 65900 nM
Compound 3: the middle estimate sits 3.7-fold (0.56 log units) below what was measured; the measured number lies above the stated range.
By their numbers in this assay, from the lowest: compounds 2 and 1 (each within the scatter of the next); then compound 3.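

In this assay the group on the carbonyl carbon proves able to shift the reading: replacing cyclopropyl with piperidin-1-yl gives a 2.6-fold higher number from compound 2 to compound 3 (0.41 log units; beyond the scatter) and is a modest step, yet one beyond the scatter. This is the only single change among the compounds shown, so it gives the first direct reading for this position, and the number rises as 3 heavy atoms are replaced by 6, including a nitrogen. Nothing available explains this rise.

A single step cannot separate the effect of the nitrogen on the carbonyl carbon from that of the whole six-membered ring, and a diethylamino group or a morpholin-4-yl ring in the same place would test that. As far as these compounds go, whether the same replacement would move the number on the core of compound 1 also remains open.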